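A few compounds are considered here, and "the series" means these few. Any claim that something is new, unique, unknown or untested is made for them only; others in the source may bear on it.

Compound 1 `Cc1ccccc1Nc1nnc(Nc2nc(-c3ccc(Cl)cc3)cs2)s1` and compound 2 `Cc1ccc(Nc2nnc(Nc3nc(-c4ccc(Cl)cc4)cs3)s2)cc1` share the same core and differ only in the aryl group on one nitrogen. In a functional assay on the whole organism (strain albino) with Mus musculus as the target, in the maximal electroshock model, with a stated time of 0.5 h (on this read-out higher numbers stand for an effect only at larger amounts of compound and lower numbers for an effect already at smaller amounts), compound 1 gives 300 mg/kg and compound 2 gives 300 mg/kg; the step of no change at the digits printed from compound 1 to compound 2 (within the scatter) shows no change within the scatter, so compound 1 stands level with compound 2 on these numbers.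

Compound 3 `Cc1ccccc1Nc1nnc(Nc2nc(-c3ccccc3)cs2)s1` is still to be measured. It differs from compound 1 by hydrogen in place of chloro on an aromatic carbon. Among the measured compounds shown here, no measured step touches this position: the only measured step concerns the methylphenyl on the nitrogen, not the chloro on the other aromatic ring, and it was flat. With nothing pointing either way, the step from compound 1 to compound 3 is expected to stay within the scatter, no change at the digits printed from compound 1 to compound 3 (within the scatter).

Compound 3 is therefore estimated at 300 mg/kg in this assay, with a range from 150 mg/kg to 600 mg/kg.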

Compound 3, minimum effective dose: 300 mg/kg
For compound 3 middle estimate and measured number coincide at the digits printed, and the stated range covers the measured number.
By their numbers in this assay, from the lowest: compounds 1, 2 and 3 (each within the scatter of the next).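

The chloro on the six-membered aromatic ring now has a measured step of its own: in this assay, the exchange of 4-chlorophenyl to phenyl gives no change at the digits printed from compound 1 to compound 3 (within the scatter) and so leaves the read-out within the scatter. In this pair the chlorine is therefore not required to hold the level seen for compound 1, and both places touched so far, the methylphenyl on the nitrogen and this ring position, read flat. No measurement at hand bears on the reason for this result.

As far as these compounds go, with only these three compounds, it remains open how far the read-out depends on either aryl group. From the compounds shown here alone, whether an amine or a carboxylic acid in place of the chloro would move the read-out beyond the scatter also remains unknown.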